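The source may report more compounds than this note shows. Statements on the series, on what has been measured and on what is new or still open speak of the compounds shown alone.

For the measured compounds named here, compound 2, `C=Cc1cccc(-c2[nH]c3cc(OC)ccc3c(=O)c2C(=O)OCC)c1`, is one of two compounds measured so far. In an ADME assay on Raji cells (Homo sapiens) for cytotoxicity, read by luminescence, with a stated time of 72 h (on this read-out higher numbers stand for an effect only at larger amounts of compound and lower numbers for an effect already at smaller amounts), compound 2 gives > 21500 nM, which is a limit of the assay rather than a number. Compound 1, `CCOC(=O)c1c(-c2ccccc2)[nH]c2cc(OC)ccc2c1=O`, differs from compound 2 only by vinyl in place of hydrogen on an aromatic carbon. In this assay compound 1 gives > 21500 nM, again a limit and not a number. Going by the values given here, the single measured step, a step that the two limits leave unreadable from compound 1 to compound 2, therefore cannot be read, because of the limit of > 21500 nM in this assay, at which 2 of the 2 values shown sit. Compound 3, `CCCCOc1cccc(-c2[nH]c3cc(OC)ccc3c(=O)c2C(=O)OCC)c1`, is the compound still to be measured; compared with compound 2 it carries butoxy in place of vinyl on an aromatic carbon. Among the compounds with values here, no measured step shows how such a change acts in this assay, and both measured values sit at the limit, so the step that the limit leaves unreadable from compound 2 to compound 3 is expected to be small enough that compound 3 stays in the same region as compound 2. Compound 3 is therefore estimated at 30000 nM in this assay, with a range from 12000 nM to 80000 nM, and most likely only a limit will again be reported.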

Compound 3, half-maximal effective concentration: > 21500 nM
Compound 3: a limit, no number; the forecaster's own chance of this, stated with the estimate: 75%; the middle value is on the limit's open side.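

In this assay, for the compounds shown here, no step among compound 1, compound 2 and compound 3 can be read, because each result is a limit of the assay and not a number: the limit of > 21500 nM in this assay, at which 3 of the 3 values shown sit. The compounds shown leave open how hydrogen, vinyl and butoxy on this aromatic carbon compare, and at what concentration any of these compounds would give a measurable effect on these cells.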